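Carboxy for Methoxy on the Anilino Ring of Compound 3

The compounds below may be only part of what the source reports. "The series", "measured", "known", "first", "only" and "open" are said of these compounds alone.

Measured compounds:
compound 1 `CC1=NN(C(=O)c2cc3ccccc3oc2=O)C(=O)C1CNc1ccc(S(N)(=O)=O)cc1` gives 68.9% in a functional assay on the whole organism for inhibition, with Rattus norvegicus as the target, read by paw edema, with stated times of 1 h and 4 h, at a dose of 0.03 mg/kg by the oral route; on this read-out lower numbers stand for less inhibition and higher numbers for more inhibition at the one dose given (going by the name of the read-out);
compound 2 `CC1=NN(C(=O)c2cc3ccccc3oc2=O)C(=O)C1CNc1ccc(Cl)cc1` gives 43.5%;
compound 3 `COc1ccc(NCC2C(=O)N(C(=O)c3cc4ccccc4oc3=O)N=C2C)cc1` gives 36.1%.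

Compound 3 has the lowest of the three numbers. Compound 2 is its nearest neighbour, and that gap, a number 7.4 percentage points lower from compound 2 to compound 3 (within the scatter), lies within the scatter; compound 1 is furthest away, and that gap, a number 32.8 percentage points lower from compound 1 to compound 3 (beyond the scatter), lies well beyond it.

Compound 4 `CC1=NN(C(=O)c2cc3ccccc3oc2=O)C(=O)C1CNc1ccc(C(=O)O)cc1` has not been measured. It differs from compound 3 in one place: carboxy in place of methoxy on an aromatic carbon.

Two measured steps change the group at this same aromatic carbon. Replacing sulfamoyl by methoxy gave a number 32.8 percentage points lower from compound 1 to compound 3 (beyond the scatter), and replacing chloro by methoxy gave a number 7.4 percentage points lower from compound 2 to compound 3 (within the scatter). Going by the values given here, the one group carrying a hydrogen-bond donor, sulfamoyl in compound 1, goes with the highest number 68.9%; carboxy also brings one hydrogen-bond donor. Compound 4 is therefore expected to move upward, by an estimated a number 15.9 percentage points higher from compound 3 to compound 4 (beyond the scatter), though the large spread between compound 1 and compound 2 leaves the size uncertain. Compound 4 is estimated at 52%, within a range of 32% to 72%.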

Compound 4, a percentage reported as inhibition, in the whole organism at one dose (the size of the read-out at that dose, not a potency): 63.6%
Compound 4: middle estimate off by 11.6 percentage points, on the low side; measured number inside the range.
By their numbers in this assay, from the lowest: compounds 3 and 2 (each within the scatter of the next); then compounds 4 and 1 (each within the scatter of the next).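

In this assay the swap of methoxy for carboxy brings a clear rise (a number 27.5 percentage points higher from compound 3 to compound 4 (beyond the scatter)), and the swap of chloro for carboxy brings another (a number 20.1 percentage points higher from compound 2 to compound 4 (beyond the scatter)), so a second group at this aromatic carbon now stands clear of both groups without a hydrogen-bond donor. Against sulfamoyl the change is only (a number 5.3 percentage points lower from compound 1 to compound 4 (within the scatter)), so carboxy and sulfamoyl cannot be told apart here. The link between a hydrogen-bond donor at this carbon and the higher numbers thus no longer rests on compound 1 alone, though nothing available explains it.

Going by these compounds, whether the donor itself counts remains open, as a methyl ester or a carboxamide at this carbon would be needed to separate it from the rest of the carboxy group. How a hydroxy or an amine would fare at this carbon is also unknown.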